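This account rests on a few compounds, and the source may have more. Where it says the series, first, only, none or still open, it means among the compounds named here.

Working notes on a small set of fused bicyclic guanylhydrazones and a related hydrazone, all tested in a functional assay on cells (Cancer cell lines, Homo sapiens) for inhibition; a lower number here means a stronger inhibitor of growth, a higher number a weaker inhibitor of growth.

Compound 1 `Cc1cc(-c2nc3n(c2/C=N/NC(=N)N)CCS3)c(C)s1` gives 38000 nM in this assay. Compound 2 `N=C(N)N/N=C/c1c(-c2ccsc2)nc2sccn12` gives 29500 nM in this assay. Compound 3 `Cc1cn2c(/C=N/Nc3ccccn3)c(-c3ccc(Cl)c([N+](=O)[O-])c3)nc2s1`, which carries a different hydrazone and a chloro-nitrophenyl group, gives 39800 nM in this assay. The three numbers lie close together; the gap from compound 2 to each of the other two is within the scatter, so no ordering among them is supported, and none of them is a strong inhibitor of growth.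

Compound 4 `Cc1cn2c(/C=N/NC(=N)N)c(-c3ccsc3)nc2s1` has not yet been measured. It differs from compound 2 by methyl in place of hydrogen on an aromatic carbon. Within the data shown here, no pair of measured compounds differing in a single place is available, so the effect of this change has not been seen here. Given how little the three measured numbers move across larger changes, the step of a 1.0-fold higher number from compound 2 to compound 4 (0.01 log units; within the scatter) is expected to stay within the scatter, in either direction. Compound 4 is therefore estimated at 30000 nM in this assay, with a range from 10000 nM to 90000 nM.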

Compound 4, concentration for total growth inhibition: 28200 nM
Compound 4: middle estimate off by 1.1-fold (0.03 log units), on the high side; the range from low to high includes it.
By their numbers in this assay, from the lowest: compounds 4, 2, 1 and 3 (each within the scatter of the next).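

The pair of compound 2 and compound 4 gives the series its first single-place comparison: in this assay, methyl in place of hydrogen on an aromatic carbon, next to the ring sulfur, gives a 1.0-fold lower number from compound 2 to compound 4 (0.02 log units; within the scatter) and so no resolved effect. At this position, then, one added carbon leaves growth inhibition indistinguishable from that of the hydrogen compound, and compound 4 remains a weak inhibitor of growth. No supporting evidence bears on this result.

Still open, going by these compounds, is whether an ethyl group, a longer chain, an amine or a carboxylic acid at this position would separate from hydrogen in this assay. The methyl step also says nothing about how this change reads on a core carrying a different aryl group or hydrazone.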